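A few compounds are considered here, and "the series" means these few. Any claim that something is new, unique, unknown or untested is made for them only; others in the source may bear on it.

Measured compounds in this study:
compound 1, `COc1cccc(-c2cc(C)cn3c(CSCCc4ccccc4)cnc23)c1`, with > 50 ug/mL, a limit of the assay rather than a number
compound 2, `c1ccc(CCSCc2cnc3ccc(-c4ccccc4)cn23)cc1`, with 9.9 ug/mL
compound 3, `Cc1cc(-c2cccc([N+](=O)[O-])c2)cn2c(CSCCc3ccccc3)cnc12`, with 43 ug/mL

In an ADME assay on HEL cells (Homo sapiens) for cytotoxicity, with a stated time of 3 days (a higher number here means that more compound is tolerated, a lower number that less compound is tolerated), compound 1 sits at > 50 ug/mL, which is a limit of the assay and not a measured number. That puts compound 1 at the limit of > 50 ug/mL in this assay, at which 1 of the 3 values shown sits. Compound 3 gives 43 ug/mL in this assay. Among the compounds with values here, compound 2 gives 9.9 ug/mL, the lowest value among the three, and it differs from the other two in more than one place, so no single step is drawn to it.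

Compound 4, `Cc1cc(-c2cccc(O)c2)c2ncc(CSCCc3ccccc3)n2c1`, differs from compound 1 by one small change: hydrogen in place of methyl on an oxygen on an aromatic ring. Within the data shown here, no pair of measured compounds shows this change, so its effect in this assay is unknown from the data at hand. Since compound 1 only shows a limit, the step in this assay is expected to be small, within the scatter or a modest decrease, with compound 4 estimated at 45 ug/mL, in a range from 20 ug/mL to 100 ug/mL. That estimate for compound 4 means a step of an at least 1.1-fold lower number from compound 1 to compound 4 (0.04 log units; that floor lies within the scatter), and a limit is again quite possible.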

Compound 4, half-maximal cytotoxic concentration: 11.4 ug/mL
Compound 4: the middle estimate sits 3.9-fold (0.60 log units) above what was measured; the measured number lies below the stated range.
By their numbers in this assay, from the lowest: compounds 2 and 4 (each within the scatter of the next); then compound 3. At a limit, above all of these: compound 1.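

Going from methoxy to hydroxy, 3-methoxyphenyl to 3-hydroxyphenyl, is the only single-place change among these compounds, and in this assay it gives an at least 4.3-fold lower number from compound 1 to compound 4 (0.64 log units; beyond the scatter). This shows that hydrogen in place of methyl on an oxygen on an aromatic ring, a change of just one carbon, is enough to shift this number beyond the usual scatter, towards less compound being tolerated. The true size of the step may be larger, since compound 1 stands at a limit and not at a measured number: the limit of > 50 ug/mL in this assay, at which 1 of the 4 values shown sits.

The compounds shown leave open whether an amine or a carboxylic acid in place of the hydroxy, or an ethoxy group with its longer chain on the oxygen, would shift the number in the same way. They also do not show whether this same change would have a similar effect on a different core.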